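A few compounds are considered here, and "the series" means these few. Any claim that something is new, unique, unknown or untested is made for them only; others in the source may bear on it.

Measured so far:
compound 1 `CN(Cc1nc2cc(C(F)(F)F)ccc2nc1-c1ccccc1)c1ccc(OC(F)(F)F)cc1` — 3000 nM
compound 2 `COc1ccc(N(C)Cc2nc3cc(C(F)(F)F)ccc3nc2-c2ccccc2)cc1OC` — 8000 nM

Going by the values given here, in an assay on isolated protein for inhibition of Dihydrofolate reductase (Homo sapiens), read by spectrophotometry (a lower number here means a stronger inhibitor, a higher number a weaker inhibitor), compound 2 stands at the highest number of the two, with compound 1 the only neighbour, at a lower number; that step, a 2.7-fold higher number from compound 1 to compound 2 (0.43 log units; beyond the scatter), came with 3,4-dimethoxyphenyl in place of 4-(trifluoromethoxy)phenyl on the amine nitrogen. Compound 3 `COc1cc(N(C)Cc2nc3cc(C(F)(F)F)ccc3nc2-c2ccccc2)cc(OC)c1OC` carries methoxy in place of hydrogen on an aromatic carbon. Among the compounds with values here, no measured step adds a methoxy to this ring; the single step seen swapped the whole aryl group and bears only indirectly, so a change within the scatter is expected, in either direction. Compound 3 is estimated at 6000 nM in this assay, range 2000 nM to 20000 nM, a step of a 1.3-fold lower number from compound 2 to compound 3 (0.12 log units; within the scatter).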

Compound 3, inhibition constant: 5000 nM
Compound 3: the middle estimate sits 1.2-fold (0.08 log units) above what was measured, and the stated range covers the measured number.
By their numbers in this assay, from the lowest: compounds 1, 3 and 2 (each within the scatter of the next, the first and the last beyond it).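

In this assay, methoxy in place of hydrogen on this aromatic carbon, ortho to a methoxy group and meta to a large group, gives a 1.6-fold lower number from compound 2 to compound 3 (0.20 log units; within the scatter). The earlier step swapped the whole aryl group, whereas this one isolates a single position, and this aromatic carbon takes a methoxy with no shift beyond the scatter. No available data explain this result. Open, as far as these compounds go, is whether a hydroxyl, an amine or a carboxylic acid on this carbon would move the number beyond the scatter.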